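A few compounds are considered here, and "the series" means these few. Any claim that something is new, unique, unknown or untested is made for them only; others in the source may bear on it.

Measured compounds: compound 1 `CCCCCCCCCCCCCCCCCCNC(=O)[C@H]1CSC(c2c[nH]c3ccccc23)N1`, compound 2 `CCCCCCCCCCCCCCCCCCNC(=O)[C@H]1CSC(c2ccc([N+](=O)[O-])cc2)N1`, compound 3 `CCCCCCCCCCCCCCCCCCNC(=O)[C@H]1CSC(c2cc(F)cc(F)c2)N1`. In a functional assay on DU-145 cells (Homo sapiens) for antiproliferative activity, read by sulforhodamine B assay (a higher number here means a weaker inhibitor, a lower number a stronger inhibitor), compound 1 gives 8900 nM and compound 2 gives 15300 nM. Compound 3 gives only the limit of > 20000 nM, so no number is known for it. It therefore sits at the limit of > 20000 nM in this assay, at which 1 of the 3 values shown sits. Of the measured steps, an at least 2.2-fold higher number from compound 1 to compound 3 (0.35 log units; beyond the scatter) was at least modest, whereas a 1.7-fold higher number from compound 1 to compound 2 (0.24 log units; within the scatter) and an at least 1.3-fold higher number from compound 2 to compound 3 (0.11 log units; that floor lies within the scatter) stayed within the scatter. Compound 4 `CCCCCCCCCCCCCCCCCCNC(=O)[C@H]1CSC(c2c(Cl)cccc2Cl)N1` carries 2,6-dichlorophenyl in place of 3,5-difluorophenyl on a saturated ring carbon. Among the measured compounds shown here, the steps that bear on this change all end at compound 3, each pointing toward a higher number. For the measured compounds named here, no measured step involves a chlorine-bearing group, so the expected step that the limit leaves unreadable from compound 3 to compound 4 is no change beyond the scatter. Compound 4 is estimated at 22000 nM, with a range from 8000 nM to 60000 nM, and a limit-only result is considered likely.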

Compound 4, half-maximal inhibitory concentration: > 20000 nM
Compound 4 ended at the assay's limit; the forecaster's own chance of this, stated with the estimate: 55%; the middle value lies beyond the limit too.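

In this assay, compound 4 also stops at a limit rather than a number, as compound 3 does: the limit of > 20000 nM in this assay, at which 2 of the 4 values shown sit. The step between these two compounds cannot be read, so 2,6-dichlorophenyl and 3,5-difluorophenyl on this saturated ring carbon cannot be ordered. Against 1H-indol-3-yl, 2,6-dichlorophenyl gives an at least 2.2-fold higher number from compound 1 to compound 4 (0.35 log units; beyond the scatter), while against 4-nitrophenyl it gives an at least 1.3-fold higher number from compound 2 to compound 4 (0.11 log units; that floor lies within the scatter).

Going by these compounds, it remains open whether a phenyl carrying an amine or a carboxylic acid at this carbon would give a stronger number than 1H-indol-3-yl. On these data alone, the effect of a different chain on the shared core also remains open.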